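The source may report more compounds than this note shows. Statements on the series, on what has been measured and on what is new or still open speak of the compounds shown alone.

Compounds 1, 2 and 3 share the same core and differ only in the group attached to one aromatic carbon. Compound 1 `Cc1nc(-c2ccc(C(F)(F)F)cc2)sc1CNc1ccc(CC(C)C(=O)O)cc1` carries a 2-carboxypropyl group, and in a functional assay on CHO cells for agonist activity at Free fatty acid receptor 1 (Homo sapiens) (a lower number here means that less compound is needed, a higher number that more compound is needed for the effect), compound 1 gives 355 nM. Compound 2 `Cc1nc(-c2ccc(C(F)(F)F)cc2)sc1CNc1ccc([C@H]2C[C@@H]2C(N)=O)cc1` carries a 2-carbamoylcyclopropyl group instead; in this assay compound 2 gives 4.47 nM, which is a 79-fold lower number from compound 1 to compound 2 (1.90 log units; beyond the scatter). Compound 3 `Cc1nc(-c2ccc(C(F)(F)F)cc2)sc1CNc1ccc([C@H]2C[C@@H]2C(=O)N(C)C)cc1` carries a 2-(dimethylcarbamoyl)cyclopropyl group, and in this assay compound 3 gives 66.1 nM. That is a 5.4-fold lower number from compound 1 to compound 3 (0.73 log units; beyond the scatter), yet also a 15-fold higher number from compound 2 to compound 3 (1.17 log units; beyond the scatter). Compound 3 therefore stands second highest of the three numbers, nearer to compound 1 than to compound 2.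

Compound 4 `Cc1nc(-c2ccc(C(F)(F)F)cc2)sc1CNc1ccc([C@H]2C[C@@H]2C(=O)N[C@H](C)c2ccccc2)cc1` differs from compound 3 in one place: (1-phenylethyl)amino in place of dimethylamino on a carbonyl carbon. Within the data shown here, the only measured step that bears on this position is a 15-fold higher number from compound 2 to compound 3 (1.17 log units; beyond the scatter), which shows that replacing the amino group on the carbonyl carbon with a dimethylamino group raised the number strongly. Among the measured compounds shown here, compound 4 brings back one hydrogen-bond donor on that nitrogen but adds a far larger group with an aromatic ring, and no measured compound shows how such a group behaves here. The expectation is therefore a modest lowering, a 2.2-fold lower number from compound 3 to compound 4 (0.34 log units; beyond the scatter), with wide uncertainty. Compound 4 is estimated at 30 nM, expected to fall between 7 nM and 150 nM.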

Compound 4, half-maximal effective concentration: 53.7 nM
Beside the measured number, compound 4's estimate is 1.8-fold (0.25 log units) below it; measured number inside the range.
By their numbers in this assay, from the lowest: compound 2; then compounds 4 and 3 (each within the scatter of the next); then compound 1.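

Swapping dimethylamino for (1-phenylethyl)amino on the carbonyl carbon adds a six-membered aromatic ring, a hydrogen-bond donor and a defined stereocentre, yet it gives a 1.2-fold lower number from compound 3 to compound 4 (0.09 log units; within the scatter) in this assay and so leaves the read-out without a change that can be told from scatter. Seen from the unsubstituted amide, placing 1-phenylethyl on the amide-type nitrogen gives a 12-fold higher number from compound 2 to compound 4 (1.08 log units; beyond the scatter) and so shows that a hydrogen-bond donor on that nitrogen is not enough on its own to keep the low number of compound 2 in this series. Nothing in the data shown explains why two such different groups give numbers within the scatter of each other.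

The compounds shown leave open whether methylamino, with a single methyl on the amide nitrogen, would stay close to compound 2 or move towards compound 3 and compound 4. They also leave open how a benzylamino group, without the methyl of the 1-phenylethyl group, or the opposite configuration at that stereocentre would behave at this carbonyl carbon.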